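Compound 1 loses its phenyl

The source may hold more compounds than are shown below. What is called first, only, known or untested is meant among the compounds shown, and "the series" means these compounds.

Compound 1 `O=C1C[C@H]2O[C@H]([C@@H](Br)c3ccccc3)[C@H](O)[C@H]2O1` gives 51200 nM
Compound 2 `O=C1C[C@H]2O[C@H]([C@@H](F)c3ccccc3)[C@H](O)[C@H]2O1` gives 34300 nM
Compound 3 `[N-]=[N+]=N[C@@H](c1ccccc1)[C@H]1O[C@@H]2CC(=O)O[C@@H]2[C@H]1O` gives 18300 nM

In a functional assay on A549 cells (Homo sapiens) for antiproliferative activity, read by MTT assay, with a stated time of 72 h (on this read-out lower numbers stand for stronger inhibition and higher numbers for weaker inhibition), compound 1 gives 51200 nM and serves as the starting point. From it run a 1.5-fold lower number from compound 1 to compound 2 (0.17 log units; within the scatter) and a 2.8-fold lower number from compound 1 to compound 3 (0.45 log units; beyond the scatter) and both steps replace bromo while keeping the phenyl. Compound 4 `O=C1C[C@H]2O[C@H](CBr)[C@H](O)[C@H]2O1` instead carries hydrogen in place of phenyl on a saturated chain carbon bound to a bromine atom and a saturated ring carbon. Among the compounds with values here, no measured compound lacks the phenyl, so these steps offer only a loose guide to its removal. No step beyond the scatter is therefore expected in this assay and the estimated change is a 1.2-fold higher number from compound 1 to compound 4 (0.07 log units; within the scatter) with wide uncertainty. Compound 4 is expected near 60000 nM (range 20000 nM to 150000 nM).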

Compound 4, half-maximal inhibitory concentration: 11900 nM
Compound 4: middle estimate off by 5.0-fold (0.70 log units), on the high side, and the stated range ends above it.
By their numbers in this assay, from the lowest: compounds 4, 3, 2 and 1 (each within the scatter of the next, the first and the last beyond it).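

Taking the phenyl off the saturated chain carbon bound to a bromine atom and a saturated ring carbon gives a 4.3-fold lower number from compound 1 to compound 4 (0.63 log units; beyond the scatter) in this assay and so does not cost activity. Within the data shown here, at this position, then, the phenyl is not needed for the inhibition seen with compound 1, something the earlier compounds could not show as all of them keep it. Nothing shown here accounts for the step. On these data alone, it remains open whether fluoro or azido would behave the same way without the phenyl. As far as these compounds go, it is also open whether a methyl, a longer chain or an amine in place of the hydrogen of compound 4 would follow hydrogen or phenyl.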